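Replacing the fluoropyridine of compound 3 with a 1,2-thiazole

The source may hold more compounds than are shown below. What is called first, only, known or untested is meant among the compounds shown, and "the series" means these compounds.

Three compounds that share one core and differ only in the fluoropyridinyl group on an oxygen have been measured in an ADME assay on the whole organism (Rattus norvegicus) for pharmacokinetics, using cassette dosing, at a dose of 1 mg/kg by the oral route; a lower number here means that a smaller share of the oral dose reaches the circulation, a higher number that a larger share of the oral dose reaches the circulation. There compound 1 `C[C@@H](Cn1c(=O)[nH]/c(=N\c2ccc(Oc3ccc(F)cn3)cc2)n(Cc2ccc(Cl)cc2)c1=O)C(=O)O` gives 82.4%, compound 2 `C[C@@H](Cn1c(=O)[nH]/c(=N\c2ccc(Oc3cccc(F)n3)cc2)n(Cc2ccc(Cl)cc2)c1=O)C(=O)O` gives 60% and compound 3 `C[C@@H](Cn1c(=O)[nH]/c(=N\c2ccc(Oc3ccnc(F)c3)cc2)n(Cc2ccc(Cl)cc2)c1=O)C(=O)O` gives 43.2%. That places compound 3 lowest of the three. The gap to the top value is a number 39.2 percentage points lower from compound 1 to compound 3 (beyond the scatter), and the gap to the middle value is a number 16.8 percentage points lower from compound 2 to compound 3 (beyond the scatter). The remaining pair is separated by a number 22.4 percentage points lower from compound 1 to compound 2 (beyond the scatter).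

Compound 4 `C[C@@H](Cn1c(=O)[nH]/c(=N\c2ccc(Oc3ccsn3)cc2)n(Cc2ccc(Cl)cc2)c1=O)C(=O)O` is the next to be measured. It carries 1,2-thiazol-3-yl in place of 2-fluoropyridin-4-yl on an oxygen on an aromatic ring. Going by the values given here, no measured step involves a five-membered ring, so these three steps only gauge how far changes to this group have moved the numbers, from modest to large. Compound 3 at 43.2% sits at the bottom of the measured range, which makes a rise look likelier than a fall, though nothing measured fixes the direction. A modest upward change is expected, a number 11.8 percentage points higher from compound 3 to compound 4 (beyond the scatter). In this assay the estimated value for compound 4 is 55%, with an expected range from 30% to 80%.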

Compound 4, oral bioavailability in the Rattus norvegicus assay: 87.6%
Compound 4: the middle estimate sits 32.6 percentage points below what was measured, outside the stated range (above it).
By their numbers in the Rattus norvegicus assay, from the lowest: compound 3; then compound 2; then compounds 1 and 4 (each within the scatter of the next).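

In the Rattus norvegicus assay, the change from a six-membered to a five-membered aromatic ring on this oxygen is not penalised, and 1,2-thiazol-3-yl gives a number 44.4 percentage points higher from compound 3 to compound 4 (beyond the scatter) and a number 27.6 percentage points higher from compound 2 to compound 4 (beyond the scatter). Against the best of the fluoropyridines the result is a number 5.2 percentage points higher from compound 1 to compound 4 (within the scatter), so the two groups cannot be told apart here, and this position is shown to accept more than the fluoropyridinyl groups seen earlier. In a physicochemical assay for solubility, at pH 1.2 (a lower number here means a less soluble compound, a higher number a more soluble compound), compound 3 gives 2.2 ug/mL and compound 4 gives 0.8 ug/mL, so the same change runs the opposite way, and within this pair the larger oral share does not go with higher solubility at this pH: the measured solubility of compound 3, 2.2 ug/mL, and of compound 4, 0.8 ug/mL, a 2.8-fold lower number (0.44 log units; beyond the scatter)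

The compounds shown do not separate ring size, the sulfur and the loss of the fluorine, so it stays open whether a plain phenyl or a 1,2-oxazol-3-yl on the same oxygen would hold the oral share of compound 4. On these data alone, it is also open whether the step from 2-fluoropyridin-4-yl to 1,2-thiazol-3-yl would carry over to a compound with an amide in place of the carboxylic acid.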